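Methoxy for methyl on the N-aryl of compound 3

The compounds below may be only part of what the source reports. "The series", "measured", "known", "first", "only" and "open" are said of these compounds alone.

Measured compounds:
Compound 1, `CC(C)(C)OC(=O)N1CCN(C(=S)SCc2cn(Cc3ccc(Cl)cc3)nn2)CC1`, gives 2960 nM in a functional assay on MCF7 cells (Homo sapiens) for inhibition, read by MTT assay, with a stated time of 72 h; a higher number here means a weaker inhibitor, a lower number a stronger inhibitor.
Compound 2, `CC(C)(C)OC(=O)N1CCN(C(=S)SCc2cn(Cc3cc(=O)oc4cc(O)ccc34)nn2)CC1`, gives 10400 nM in this assay.
Compound 3, `Cc1ccc(-n2cc(CSC(=S)N3CCN(C(=O)OC(C)(C)C)CC3)nn2)cc1`, gives 74200 nM in this assay.

Compound 3 stands highest of the three numbers in this assay: compound 2 lies nearest, and compound 1 furthest, both beyond the scatter. Among the compounds with values here, the single one-point step known here, a 25-fold higher number from compound 1 to compound 3 (1.40 log units; beyond the scatter), concerns the group on the aromatic nitrogen and does not touch the change now considered.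

Compound 4, `COc1ccc(-n2cc(CSC(=S)N3CCN(C(=O)OC(C)(C)C)CC3)nn2)cc1`, differs from compound 3 as follows: methoxy in place of methyl on an aromatic carbon. Within the data shown here, no measured pair shows a methoxy in place of a methyl, so there is no direct precedent for this step in this assay. With nothing to point either way, the expectation is a step of about no size beyond the scatter, a 1.2-fold lower number from compound 3 to compound 4 (0.09 log units; within the scatter), with a wide range to admit a real but modest shift in either direction.

The estimate for compound 4 in this assay is therefore 60000 nM, lying between 20000 nM and 180000 nM.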

Compound 4, half-maximal inhibitory concentration: 93100 nM
Beside the measured number, compound 4's estimate is 1.6-fold (0.19 log units) below it; the measured number falls inside the stated range.
By their numbers in this assay, from the lowest: compound 1; then compound 2; then compounds 3 and 4 (each within the scatter of the next).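

In this assay the change from 4-methylphenyl to 4-methoxyphenyl gives a 1.3-fold higher number from compound 3 to compound 4 (0.10 log units; within the scatter) and so, on this aromatic carbon, the methoxy group cannot be told from the methyl group. Compound 4 also joins compound 3 in lying far from compound 1: the data show a 31-fold higher number from compound 1 to compound 4 (1.50 log units; beyond the scatter) alongside a 25-fold higher number from compound 1 to compound 3 (1.40 log units; beyond the scatter) and so the large distance from the 4-chlorobenzyl compound holds for both of these substituted phenyl groups. Nothing available explains either the small step or the large ones.

The compounds shown leave open whether an amine or a carboxylic acid at this same place would move the number beyond the scatter. They also leave open how the large steps divide between the chlorine and the extra carbon of the benzyl group, which 4-chlorophenyl and 4-methylbenzyl groups could separate.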